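This account rests on a few compounds, and the source may have more. Where it says the series, first, only, none or still open, it means among the compounds named here.

Measured compounds:
- compound 1 `O=C1/C(=C/c2ccccc2F)CN(Cc2cn(Cc3ccc(F)cc3)nn2)C/C1=C\c1ccccc1F`: 6000 nM
- compound 2 `COc1ccc(/C=C2\CN(Cc3cn(Cc4cccc(Cl)c4)nn3)C/C(=C\c3ccc(OC)cc3)C2=O)cc1`: 99000 nM

For the measured compounds named here, in a functional assay on MCF7 cells (Homo sapiens) for cytotoxicity, read by MTT assay, with a stated time of 24 h (a lower number here means a stronger inhibitor, a higher number a weaker inhibitor), compound 1 gives 6000 nM, the lower of the two numbers measured so far, and the gap to compound 2 lies beyond the usual scatter. In the same assay compound 2 gives 99000 nM. The two compounds differ in several places at once, so nothing can be read from them about any single change.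

Compound 3 `O=C1/C(=C/c2ccccc2F)CN(Cc2cn(Cc3ccccc3F)nn2)C/C1=C\c1ccccc1F` is not yet measured. It differs from compound 1 in one place: 2-fluorophenyl in place of 4-fluorophenyl on a saturated chain carbon bound to an aromatic nitrogen. Going by the values given here, no measured pair shows the effect of moving the fluorine on this benzyl group, so no step of this kind is known. With the same atoms joined differently and the rest of the molecule unchanged, the step of no change at the digits printed from compound 1 to compound 3 (within the scatter) from compound 1 to compound 3 is expected to stay within the scatter. Compound 3 is therefore estimated at 6000 nM, with a range from 2000 nM to 18000 nM.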

Compound 3, half-maximal inhibitory concentration: 6000 nM
Compound 3: the middle estimate sits on the measured number at the digits printed; the range from low to high includes it.
By their numbers in this assay, from the lowest: compounds 1 and 3 (each within the scatter of the next); then compound 2.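

In this assay, for the compounds shown here, the first step in one place runs no change at the digits printed from compound 1 to compound 3 (within the scatter) and so does not separate 4-fluorobenzyl from 2-fluorobenzyl at this position, on a saturated chain carbon bound to an aromatic nitrogen. The earlier pair differed in several places at once and could show nothing about this group alone, whereas here moving the fluorine around the ring leaves the cytotoxicity reading unchanged within the scatter. Nothing given here offers an explanation for this result.

On these data alone, it remains open whether this tolerance extends to other groups on the same ring, such as an amine or a carboxylic acid, or to a longer chain in place of the benzyl carbon. The compounds shown also leave unresolved which of the several differences between compound 1 and compound 2 accounts for the gap in their numbers.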